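The source may hold more compounds than are shown below. What is called first, only, known or untested is meant among the compounds shown, and "the series" means these compounds.

Measured so far in a functional assay on Ramos cells (Homo sapiens) for antiproliferative activity, read by CCK-8 assay, with a stated time of 72 h, tested at 40 uM; on this read-out higher numbers stand for more inhibition at the one concentration tested (going by the name of the read-out) and lower numbers for less inhibition:
compound 1, `CN1CCN(c2ccc(Nc3nc(-c4cccc(NC(=O)c5ccccc5)c4)sc3C(=O)O)cc2)CC1`: 26.3%
compound 2, `CN1CCN(c2ccc(Nc3nc(-c4cccc(NC(=O)c5ccccc5F)c4)sc3C(=O)O)cc2)CC1`: 93.4%
compound 3, `CN1CCN(c2ccc(Nc3nc(-c4cccc(NC(=O)c5ccccc5)c4)sc3C(N)=O)cc2)CC1`: 98.1%

Compound 2 differs from compound 1 by fluoro in place of hydrogen on an aromatic carbon, and this gave a number 67.1 percentage points higher from compound 1 to compound 2 (beyond the scatter). Compound 3 differs from compound 1 in its core by amino in place of hydroxy on a carbonyl carbon, with a number 71.8 percentage points higher from compound 1 to compound 3 (beyond the scatter). Compound 2 and compound 3 lie within the scatter of each other.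

Compound 4, `CN1CCN(c2ccc(Nc3nc(-c4cccc(NC(=O)c5cccc(F)c5)c4)sc3C(N)=O)cc2)CC1`, differs from compound 3 by fluoro in place of hydrogen on an aromatic carbon. This is the same kind of change as from compound 1 to compound 2, but not the same: there the fluoro sits ortho to a large group, here meta to a large group. The earlier step was large, yet it started from a low number. The step of a number 2.1 percentage points lower from compound 3 to compound 4 (within the scatter) is expected to be small, since compound 3 already gives 98.1% and little room remains on this read-out. Compound 4 is therefore expected to give 96%, within 84% to 100%.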

Compound 4, a percentage reported as inhibition, at one concentration (the size of the read-out at that concentration, not a potency): 16.2%
Beside the measured number, compound 4's estimate is 79.8 percentage points above it; measured number below the stated range.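

In this assay, fluoro in place of hydrogen on the core of compound 3 gives a number 81.9 percentage points lower from compound 3 to compound 4 (beyond the scatter), so this change cannot be carried from one core to the other with its direction or size intact: the same change on two cores in this assay, a number 67.1 percentage points higher (beyond the scatter) from compound 1 to compound 2 and a number 81.9 percentage points lower (beyond the scatter) from compound 3 to compound 4, 149 percentage points apart, beyond the scatter of two such steps

This does not show what causes the reversal. Compound 4 carries a 3-fluorophenyl group, whereas the fluoro of compound 2 stands at another place on the ring, so core and fluoro position change together between the two steps.

Still open, as far as these compounds go, is how a 3-fluorophenyl group behaves on the core of compound 1, and how the fluorinated ring of compound 2 behaves on the core of compound 3. Also open, from the compounds shown here alone, is whether chloro or methyl at these places would follow fluoro.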